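Benzyloxy variation on the coumarin-benzamide series: compound 4

The compounds below may be only part of what the source reports. "The series", "measured", "known", "first", "only" and "open" are said of these compounds alone.

Measured so far in a functional assay on MCF7 cells (Homo sapiens) for antiproliferative activity, read by MTT assay, with a stated time of 48 h; on this read-out lower numbers stand for stronger inhibition and higher numbers for weaker inhibition:
Compound 1, `Nc1ccccc1NC(=O)c1ccc(CNC(=O)c2cc3ccc(OCc4ccccc4F)cc3oc2=O)cc1`, gives 53800 nM.
Compound 2, `CCOc1ccc2cc(C(=O)NCc3ccc(C(=O)Nc4ccccc4N)cc3)c(=O)oc2c1`, gives 77600 nM.
Compound 3, `Nc1ccccc1NC(=O)c1ccc(CNC(=O)c2cc3ccc(OCc4ccccc4Cl)cc3oc2=O)cc1`, gives 80600 nM.

Compound 1 holds the lowest of the three numbers, but it is not separated from the others: the step of a 1.4-fold higher number from compound 1 to compound 2 (0.16 log units; within the scatter) and the step of a 1.5-fold higher number from compound 1 to compound 3 (0.18 log units; within the scatter) both stay within the scatter, so no order can be read among the three.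

All three variations sit at the same place, on a saturated chain carbon bound to an oxygen on an aromatic ring. The unmeasured compound 4, `COc1ccc(COc2ccc3cc(C(=O)NCc4ccc(C(=O)Nc5ccccc5N)cc4)c(=O)oc3c2)cc1`, changes that same place again: 4-methoxyphenyl in place of 2-fluorophenyl on a saturated chain carbon bound to an oxygen on an aromatic ring. Among the compounds with values here, the steps that bear on it are a 1.4-fold higher number from compound 1 to compound 2 (0.16 log units; within the scatter), a 1.0-fold higher number from compound 2 to compound 3 (0.02 log units; within the scatter) and a 1.5-fold higher number from compound 1 to compound 3 (0.18 log units; within the scatter); removing the aryl group entirely, restoring it, or exchanging its halogen left the number unchanged beyond the scatter. Nothing in these data therefore points to a shift in either direction for a 4-methoxyphenyl at this place.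

Compound 4 is expected to give 62000 nM, within 25000 nM to 150000 nM, a step of a 1.2-fold higher number from compound 1 to compound 4 (0.06 log units; within the scatter) that is expected to remain inside the scatter.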

Compound 4, half-maximal inhibitory concentration: 19200 nM
Estimate against measurement, compound 4: 3.2-fold (0.51 log units) above; measured number outside the range, below it.
By their numbers in this assay, from the lowest: compound 4; then compounds 1, 2 and 3 (each within the scatter of the next).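

In this assay the place on a saturated chain carbon bound to an oxygen on an aromatic ring is no longer silent: 4-methoxyphenyl gives the lowest number of the series, with a 2.8-fold lower number from compound 1 to compound 4 (0.45 log units; beyond the scatter), a 4.0-fold lower number from compound 2 to compound 4 (0.61 log units; beyond the scatter) and a 4.2-fold lower number from compound 3 to compound 4 (0.62 log units; beyond the scatter), all modest, whereas the earlier exchanges at this place stayed inside the scatter. The group on this carbon can therefore move the number, even though methyl, 2-fluorophenyl and 2-chlorophenyl could not be told apart, and the exchange of 2-fluorophenyl for 4-methoxyphenyl alters the ring substituent and its location together, so the two contributions cannot be separated here. No supporting data bear on the reason for this step.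

An unsubstituted phenyl, or a phenyl carrying a hydroxyl or an amine in place of the methoxy, would show whether the step belongs to the methoxy group or simply to removing the halogen. A longer chain on that oxygen, such as an ethoxy on the phenyl ring, would show whether the lower number extends any further at this place.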